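From Trifluoromethyl to Cyano on the Fused Ring

The source may report more compounds than this note shows. Statements on the series, on what has been measured and on what is new or still open speak of the compounds shown alone.

Among the measured compounds shown here, compound 2 `C[C@@H]1CN(c2nnc(Cc3ccccc3)c3cc(C(F)(F)F)ccc23)CCN1c1ccc(C#N)cn1` gives 12000 nM in an assay on Sf9 cells for inhibition of sphingosine-1-phosphate lyase 1 (Homo sapiens), with a stated time of 1 h (on this read-out lower numbers stand for stronger inhibition and higher numbers for weaker inhibition), the highest of the two numbers measured so far; its nearest neighbour is compound 1 `C[C@@H]1CN(c2nnc(Cc3ccccc3)c3cc(Cl)ccc23)CCN1c1ccc(C#N)cn1`, which gives 2300 nM. Compound 3 `C[C@@H]1CN(c2nnc(Cc3ccccc3)c3cc(C#N)ccc23)CCN1c1ccc(C#N)cn1` differs from compound 2 by cyano in place of trifluoromethyl on an aromatic carbon. For the measured compounds named here, the only step measured, a 5.2-fold higher number from compound 1 to compound 2 (0.72 log units; beyond the scatter), concerns a different exchange at the same place and does not directly cover swapping trifluoromethyl for cyano. Lacking a closely matching step, compound 3 is expected to give 4000 nM, within a range from 1500 nM to 15000 nM, which corresponds to an estimated 3.0-fold lower number from compound 2 to compound 3 (0.48 log units; beyond the scatter).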

Compound 3, half-maximal inhibitory concentration: 1300 nM
Beside the measured number, compound 3's estimate is 3.1-fold (0.49 log units) above it; the whole stated range lies above it.
By their numbers in this assay, from the lowest: compounds 3 and 1 (each within the scatter of the next); then compound 2.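

At this position, trifluoromethyl now stands apart from two other groups: in this assay, cyano in its place gives a clear change (a 9.2-fold lower number from compound 2 to compound 3 (0.97 log units; beyond the scatter)). Cyano and chloro cannot be told apart (a 1.8-fold lower number from compound 1 to compound 3 (0.25 log units; within the scatter)), so two different groups here give matching results. No supporting measurement explains why trifluoromethyl differs. Going by these compounds, whether an amine or a carboxylic acid at this place would match cyano and chloro or match trifluoromethyl stays open. Also open, on these data alone, is whether these exchanges would behave alike with other parts of the compounds changed.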